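The source may hold more compounds than are shown below. What is called first, only, known or untested is meant among the compounds shown, and "the series" means these compounds.

The measured compounds, all with the same core:

compound 1, `COc1cccc(C(C)Sc2nc3c(cnn3C)c(=O)n2-c2ccccc2)c1`, 451 nM
compound 2, `CC(Sc1nc2c(cnn2C)c(=O)n1-c1ccc(CO)cc1)c1ccccc1`, 600 nM
compound 3, `CC(Sc1nc2c(cnn2C)c(=O)n1-c1ccc(CCO)cc1)c1ccccc1`, 360 nM

In an assay on isolated protein for inhibition of aldehyde dehydrogenase 1A1 (Homo sapiens) (on this read-out higher numbers stand for weaker inhibition and lower numbers for stronger inhibition), compound 1 gives the second highest of the three numbers, yet it lies within the scatter of compound 2 and of compound 3 alike. Among the measured compounds shown here, the only single-point step, a 1.7-fold lower number from compound 2 to compound 3 (0.22 log units; within the scatter), concerns a different position and does not touch the group changed here. Compound 4, `CC(Sc1nc2c(cnn2C)c(=O)n1-c1ccccc1)c1cncnc1`, differs from compound 1 by pyrimidin-5-yl in place of 3-methoxyphenyl on a saturated chain carbon bound to a saturated chain carbon and a sulfur. For the measured compounds named here, no measured step bears on this exchange. With compound 1 at 451 nM as the only anchor, compound 4 is expected to give 800 nM, within 250 nM to 2500 nM, an expected step of a 1.8-fold higher number from compound 1 to compound 4 (0.25 log units; within the scatter).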

Compound 4, half-maximal inhibitory concentration in the aldehyde dehydrogenase 1A1 assay: 94 nM
Estimate against measurement, compound 4: 8.5-fold (0.93 log units) above, outside the stated range (below it).
By their numbers in the aldehyde dehydrogenase 1A1 assay, from the lowest: compound 4; then compounds 3, 1 and 2 (each within the scatter of the next).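

In the aldehyde dehydrogenase 1A1 assay, pyrimidin-5-yl in place of 3-methoxyphenyl brings a 4.8-fold lower number from compound 1 to compound 4 (0.68 log units; beyond the scatter), so the group on this chain carbon, untouched by the earlier step, clearly matters for inhibition. In a physicochemical assay for solubility, using the shake flask method, in phosphate buffer, with a stated time of 24 h, at pH 7.4 (on this read-out higher numbers stand for higher solubility and lower numbers for lower solubility), compound 1 gives < 2000 nM, which is a limit of the assay. In the physicochemical assay, compound 4 gives 264000 nM.

A single exchange cannot separate losing the methoxy group from gaining the ring nitrogens. As far as these compounds go, how a pyridin-3-yl, with one ring nitrogen, would fare at this place on both read-outs remains open.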